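The compounds below may be only part of what the source reports. "The series", "measured", "known", "first", "only" and "open" are said of these compounds alone.

Among the compounds with values here, in a functional assay on VCaP cells (Homo sapiens) for antiproliferative activity, read by propidium iodide staining, with a stated time of 96 h (on this read-out lower numbers stand for stronger inhibition and higher numbers for weaker inhibition), compound 1 (`CC(O)(CSc1ccc(S(F)(F)(F)(F)F)cc1)C(=O)Nc1cccc(S(F)(F)(F)(F)F)c1`) gives 24100 nM and compound 2 (`CC(O)(CSc1ccc(F)cc1)C(=O)Nc1cccc(S(F)(F)(F)(F)F)c1`) gives 21900 nM, so compound 2 stands level with the only other measured compound, within the scatter. The next compound, compound 3 (`CC(O)(CSc1ccc(C(F)(F)F)cc1)C(=O)Nc1cccc(S(F)(F)(F)(F)F)c1`), alters compound 2 at one place: trifluoromethyl in place of fluoro on an aromatic carbon, para to a large group. Within the data shown here, the one measured step that bears on this change is a 1.1-fold lower number from compound 1 to compound 2 (0.04 log units; within the scatter), an exchange at that same aromatic carbon. That step stayed within the scatter, so no step beyond the scatter is expected in this assay, in either direction, although a single step is thin evidence. The estimated step is a 1.0-fold higher number from compound 2 to compound 3 (0.00 log units; within the scatter). For compound 3 the expected value is 22000 nM, with an estimated range of 12000 nM to 40000 nM.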

Compound 3, half-maximal inhibitory concentration: 27300 nM
Estimate against measurement, compound 3: 1.2-fold (0.09 log units) below, and the stated range covers the measured number.
By their numbers in this assay, from the lowest: compounds 2, 1 and 3 (each within the scatter of the next).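

In this assay, the aromatic carbon para to a large group has now carried three different groups, and trifluoromethyl in place of fluoro gives a 1.2-fold higher number from compound 2 to compound 3 (0.10 log units; within the scatter). The exchange of the group of 6 heavy atoms (5 fluorine, 1 sulfur) for trifluoromethyl gives a 1.1-fold higher number from compound 1 to compound 3 (0.05 log units; within the scatter), so across these three compounds no exchange at this carbon moves the number beyond the scatter, whether the entering group is small or large. Nothing measured here offers an explanation for this flat result.

On these data alone, all three groups at this carbon contain fluorine, so it remains open whether a group without it, such as an amine or a carboxylic acid, would move the number beyond the scatter. As far as these compounds go, the effect of changes elsewhere on the shared core also remains open.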